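A few compounds are considered here, and "the series" means these few. Any claim that something is new, unique, unknown or untested is made for them only; others in the source may bear on it.

Among the compounds with values here, compound 2 `CCOc1ccc(-c2cccc(C(=O)OCCOC)c2)cc1` gives 89% in an assay on COS-7 cells for inhibition of patatin-like phospholipase domain-containing protein 2 (Mus musculus), tested at 200 uM (a lower number here means less inhibition, a higher number more inhibition at the concentration tested (going by the name of the read-out)), the higher of the two values so far; compound 1 `CCOc1ccc(-c2ccccc2)cc1` gives 35%. Within the data shown here, the sole measured step is a number 54 percentage points higher from compound 1 to compound 2 (beyond the scatter). Compound 3 `CCNC(=O)c1cccc(-c2ccc(OCC)cc2)c1` differs from compound 2 by ethylamino in place of 2-methoxyethoxy on a carbonyl carbon; the carbonyl on that aromatic carbon stays, only its outer part changes. Among the measured compounds shown here, no measured step covers this exchange, so the step from compound 1 to compound 2 is the only guide and bears on it indirectly. Compound 3 is expected to keep most of that gain, with a number 19 percentage points lower from compound 2 to compound 3 (beyond the scatter) as a moderate loss, giving an estimate of 70% within 40% to 95%.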

Compound 3, a percentage reported as inhibition, at one concentration (the size of the read-out at that concentration, not a potency): 62%
Beside the measured number, compound 3's estimate is 8 percentage points above it; measured number inside the range.
By their numbers in this assay, from the lowest: compound 1; then compound 3; then compound 2.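

At the carbonyl carbon, the outer part of the group counts in this assay: ethylamino in place of 2-methoxyethoxy gives a clear loss (a number 27 percentage points lower from compound 2 to compound 3 (beyond the scatter)). The gain over hydrogen does not depend on the (2-methoxyethoxy)carbonyl group alone, as ethylcarbamoyl also retains part of it (a number 27 percentage points higher from compound 1 to compound 3 (beyond the scatter)). No supporting data account for the difference between these two groups.

Ethylamino and 2-methoxyethoxy differ in both the atom joined to the carbonyl and the chain, so the compounds shown leave the source of the loss open. A 2-methoxyethylamino group on the same carbonyl would separate these two changes.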